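Chloro for trifluoromethyl on the urea-bearing aryl of compound 3

This account rests on a few compounds, and the source may have more. Where it says the series, first, only, none or still open, it means among the compounds named here.

Three compounds sharing one core have been run in a functional assay on UO-31 cells (Homo sapiens) for inhibition, read by sulforhodamine B assay, with a stated time of 48 h, tested at 10 uM; a higher number here means a weaker effect of the compound at the concentration tested, a lower number a stronger effect. Compound 1 `COc1cc(Cl)cc(-c2nn(-c3cccc(NC(=O)c4ccc(Cl)c(Cl)c4)c3)cc2-c2ccncc2)c1` gives 43.5%, compound 2 `O=C(Nc1cccc(-n2cc(-c3ccncc3)c(-c3cc(O)cc(Cl)c3)n2)c1)Nc1ccc(Cl)c(Cl)c1` gives -41.3%, and compound 3 `COc1cc(Cl)cc(-c2nn(-c3cccc(NC(=O)Nc4ccc(Cl)c(C(F)(F)F)c4)c3)cc2-c2ccncc2)c1` gives 11.1%. Compound 3 therefore stands second highest of the three numbers: compound 1 lies above it beyond the scatter, and compound 2 lies below it, also beyond the scatter. Among the measured compounds shown here, the one step measured in one place is a number 32.4 percentage points lower from compound 1 to compound 3 (beyond the scatter), a large move.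

Compound 4 `COc1cc(Cl)cc(-c2nn(-c3cccc(NC(=O)Nc4ccc(Cl)c(Cl)c4)c3)cc2-c2ccncc2)c1` is not yet measured. Its difference from compound 3 is chloro in place of trifluoromethyl on an aromatic carbon. For the measured compounds named here, no measured pair changes only this group, so the step from compound 1 to compound 3, which swaps both the linker and this aryl, is the only one that touches the same part of the molecule, and it does not isolate the change in question. The urea of compound 3 is kept in compound 4, so a step of modest size, in either direction, is what one would expect in this assay.

On that basis compound 4 is estimated at 2%, within -35% to 35%, which is expected to mean a step of a number 9.1 percentage points lower from compound 3 to compound 4 (within the scatter).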

Compound 4, a percentage reported as activity, at one concentration (the size of the read-out at that concentration, not a potency): 0.64%
For compound 4 the middle estimate is 1.4 percentage points above the measured one; the range from low to high includes it.
By their numbers in this assay, from the lowest: compound 2; then compound 4; then compound 3; then compound 1.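

In this assay, among the compounds shown here, the change of trifluoromethyl to chloro on the aromatic carbon, seen alone for the first time, gives a number 10.5 percentage points lower from compound 3 to compound 4 (beyond the scatter) and is a modest move that still lies beyond the scatter. With the 3,4-dichlorophenyl group held constant, the linker and the oxygen substituent can also be read singly: the change to (3,4-dichlorophenyl)amino on the carbonyl carbon gives a number 42.9 percentage points lower from compound 1 to compound 4 (beyond the scatter) and methyl in place of hydrogen on the oxygen gives a number 41.9 percentage points higher from compound 2 to compound 4 (beyond the scatter) in this assay, both large moves, so this aryl substituent shifts the read-out less than either of those two changes. Nothing on hand gives a reason for any of these moves.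

As far as these compounds go, how a nitrile, a methyl group or a bare hydrogen on the same aromatic carbon would compare with chloro and trifluoromethyl remains open. From the compounds shown here alone, it is also open whether the large step at the oxygen holds with trifluoromethyl on the aryl, and whether a longer chain such as ethyl on that oxygen would fall nearer to methyl or to hydrogen.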